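This account rests on a few compounds, and the source may have more. Where it says the series, first, only, none or still open, it means among the compounds named here.

Measured compounds in a functional assay on HT-29 cells (Homo sapiens) for cytotoxicity, read by MTT assay, with a stated time of 24 h, tested at 80 ug/mL; a higher number here means a stronger effect of the compound at the concentration tested, a lower number a weaker effect:
compound 1 `Cn1c(-c2ccc(NC(=O)CSc3nc4cc(Cl)ccc4o3)cc2)nc(-c2ccccc2)c1-c1ccccc1`, 79.6%
compound 2 `Cc1nnc(SCC(=O)Nc2ccc(-c3nc(-c4ccccc4)c(-c4ccccc4)n3C)cc2)s1`, 90.5%
compound 3 `CCN1CCN(CC(=O)Nc2ccc(-c3nc(-c4ccccc4)c(-c4ccccc4)n3C)cc2)CC1`, 51.2%

Compound 3 stands lowest of the three: it lies a number 28.4 percentage points lower from compound 1 to compound 3 (beyond the scatter) and a number 39.3 percentage points lower from compound 2 to compound 3 (beyond the scatter), both beyond the scatter. Compound 4 `Cc1ccc(CN2CCN(CC(=O)Nc3ccc(-c4nc(-c5ccccc5)c(-c5ccccc5)n4C)cc3)CC2)cc1` differs from compound 3 in one place: 4-methylphenyl in place of methyl on a saturated chain carbon bound to an amine nitrogen in a ring. Going by the values given here, no measured step bears directly on this change; the two steps that end at compound 3 both replaced a sulfur-linked heteroaryl group on the carbon bound to the carbonyl with 4-ethylpiperazin-1-yl and lowered the read-out, so an added aromatic ring may be expected to raise it in this assay, though only modestly. Compound 4 is therefore expected to give about 60% (range 42% to 78%), a step of a number 8.8 percentage points higher from compound 3 to compound 4 (within the scatter).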

Compound 4, a percentage reported as activity, at one concentration (the size of the read-out at that concentration, not a potency): 54.2%
The estimate for compound 4 lay 5.8 percentage points above the measured number; the measured number falls inside the stated range.
By their numbers in this assay, from the lowest: compounds 3 and 4 (each within the scatter of the next); then compound 1; then compound 2.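

In this assay, 4-methylbenzyl in place of ethyl on the amine nitrogen in a ring gives a number 3 percentage points higher from compound 3 to compound 4 (within the scatter). The earlier steps shown here concerned only the group on the carbon bound to the carbonyl; this one shows that, at this outer position, adding a six-membered aromatic ring of carbon only leaves the read-out indistinguishable from that of compound 3. Nothing available explains this outcome. As far as these compounds go, whether a 2-hydroxyethyl chain, a carboxylic acid or a plain benzyl at this position would separate from compound 3 remains open.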